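Fluoro to cyano on the chain of compound 3

This account rests on a few compounds, and the source may have more. Where it says the series, first, only, none or still open, it means among the compounds named here.

Of the compounds shown here, three sharing one core have been measured. In a functional assay on HT-29 cells (Homo sapiens) for inhibition, read by luminescence and CellTiter-Glo, with a stated time of 24 h (a lower number here means that less compound is needed, a higher number that more compound is needed for the effect), compound 1 `CCCn1nc(C(=O)N[C@H]2COc3ccccc3N(C)C2=S)nc1Cc1ccccc1` gives 288 nM, compound 2 `CC(C)Cn1nc(C(=O)N[C@H]2COc3ccccc3N(C)C2=S)nc1Cc1ccccc1` gives 1230 nM, and compound 3 `CN1C(=S)[C@@H](NC(=O)c2nc(Cc3ccccc3)n(CCCF)n2)COc2ccccc21` gives 4760 nM, the highest number of the three. Compound 4 `CN1C(=S)[C@@H](NC(=O)c2nc(Cc3ccccc3)n(CCCC#N)n2)COc2ccccc21` has cyano in place of fluoro on a saturated chain carbon, three bonds along the chain from an aromatic nitrogen. Placing fluoro on that carbon gave a 17-fold higher number from compound 1 to compound 3 (1.22 log units; beyond the scatter), a large step. Placing methyl on a chain carbon gave a 4.3-fold higher number from compound 1 to compound 2 (0.63 log units; beyond the scatter), a modest one. Both additions raised the number, so a high number seems likely to persist. Within the data shown here, no measured compound carries cyano, which leaves the outcome uncertain. The expected step in this assay is a 1.6-fold lower number from compound 3 to compound 4 (0.20 log units; within the scatter), with no clear change anticipated. Compound 4 is estimated at 3000 nM, within a range of 700 nM to 12000 nM.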

Compound 4, half-maximal effective concentration: 2400 nM
Estimate against measurement, compound 4: 1.3-fold (0.10 log units) above; measured number inside the range.
By their numbers in this assay, from the lowest: compound 1; then compounds 2, 4 and 3 (each within the scatter of the next, the first and the last beyond it).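

In this assay the change from fluoro to cyano at this chain position gives a 2.0-fold lower number from compound 3 to compound 4 (0.30 log units; within the scatter) and so makes no clear difference. The same holds against the branched chain of compound 2, with a 2.0-fold higher number from compound 2 to compound 4 (0.29 log units; within the scatter) as the step, while an 8.3-fold higher number from compound 1 to compound 4 (0.92 log units; beyond the scatter) shows that the cyano-bearing chain stays well apart from the plain chain of compound 1, as the chains of compound 2 and compound 3 also do. No measurement shown accounts for this.

From the compounds shown here alone, whether an amine, a carboxylic acid or a longer chain at this position would keep the higher number or return towards compound 1 remains open.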